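Swapping tert-butyl for cyclopropyl on a carbonyl carbon

A few compounds are considered here, and "the series" means these few. Any claim that something is new, unique, unknown or untested is made for them only; others in the source may bear on it.

Of the compounds shown here, three sharing one core have been tested in a physicochemical assay for solubility, read by HPLC, in phosphate buffer, measured as kinetic solubility, at pH 7.4; a lower number here means a less soluble compound, a higher number a more soluble compound. Compound 1 `CCC(=O)c1cc(-c2ccc(S(N)(=O)=O)cc2)n(-c2ccc(Cl)cc2)n1`, with ethyl on the carbonyl carbon, gives 41900 nM. Compound 2 `CCCC(=O)c1cc(-c2ccc(S(N)(=O)=O)cc2)n(-c2ccc(Cl)cc2)n1`, with propyl there, gives 25800 nM. The move between them is a 1.6-fold lower number from compound 1 to compound 2 (0.21 log units; within the scatter), so these two cannot be told apart. Compound 3 `CC(C)(C)C(=O)c1cc(-c2ccc(S(N)(=O)=O)cc2)n(-c2ccc(Cl)cc2)n1`, carrying tert-butyl, gives 6600 nM, the lowest number of the three.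

Compound 4 `NS(=O)(=O)c1ccc(-c2cc(C(=O)C3CC3)nn2-c2ccc(Cl)cc2)cc1` keeps the core and alters one group: cyclopropyl in place of tert-butyl on a carbonyl carbon. Counted out, the difference is cyclopropyl in place of tert-butyl on a carbonyl carbon.

For the measured compounds named here, no measured step involves cyclopropyl, so the nearest guides are the two steps that arrive at tert-butyl. These are a 6.3-fold lower number from compound 1 to compound 3 (0.80 log units; beyond the scatter) and a 3.9-fold lower number from compound 2 to compound 3 (0.59 log units; beyond the scatter), both modest. Read backwards, they suggest that leaving tert-butyl could raise the number, though a ring may not behave like the open chains of compound 1 and compound 2. The expected move is therefore modest and upward, a 3.3-fold higher number from compound 3 to compound 4 (0.52 log units; beyond the scatter). For compound 4 the estimate is 22000 nM, with an expected range from 9000 nM to 50000 nM.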

Compound 4, solubility: 25600 nM
Estimate against measurement, compound 4: 1.2-fold (0.07 log units) below; the range from low to high includes it.
By their numbers in this assay, from the lowest: compound 3; then compounds 4, 2 and 1 (each within the scatter of the next).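

In this assay, cyclopropyl on a carbonyl carbon falls in with the open chains and not with tert-butyl. The change from tert-butyl is beyond the scatter (a 3.9-fold higher number from compound 3 to compound 4 (0.59 log units; beyond the scatter)), whereas compound 4 cannot be told apart from the compounds carrying propyl (a 1.0-fold lower number from compound 2 to compound 4 (0.00 log units; within the scatter)) or ethyl (a 1.6-fold lower number from compound 1 to compound 4 (0.21 log units; within the scatter)). Compound 3 now stands alone in this set of four, so a ring at this place does not by itself give a number like that of tert-butyl, and nothing available gives a measured reason for the separation of tert-butyl from the other three groups.

The four compounds leave open what sets tert-butyl apart, since ethyl, propyl and cyclopropyl all differ from it in more than one way, and isopropyl or cyclobutyl on the same carbonyl carbon would show whether the number changes gradually or only at tert-butyl. They also leave open whether a longer chain, or an amine in place of these carbon groups, would stay with compound 1, compound 2 and compound 4 or move away from them.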